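This account rests on a few compounds, and the source may have more. Where it says the series, first, only, none or still open, it means among the compounds named here.

Three compounds share one core. Compound 1 `O=C(Nc1nc(-c2ccccc2)nc2c1nnn2Cc1ccccc1)c1cccc([N+](=O)[O-])c1` gives 4850 nM in an assay on CHO cells for displacement of a labelled ligand from adenosine receptor A3 (Homo sapiens), read by scintillation counting; a higher number here means a weaker inhibitor, a lower number a stronger inhibitor. Compound 2 `O=C(Nc1nc(-c2ccccc2)nc2c1nnn2Cc1ccccc1)c1ccccc1C(F)(F)F` gives 560 nM in this assay, and compound 3 `Nc1nc(-c2ccccc2)nc2c1nnn2Cc1ccccc1` gives 4220 nM in this assay. Compound 2 thus gives the lowest of the three numbers: the step of an 8.7-fold lower number from compound 1 to compound 2 (0.94 log units; beyond the scatter) lies beyond the scatter, and its gap to compound 3 is beyond the scatter as well. The step of a 1.1-fold lower number from compound 1 to compound 3 (0.06 log units; within the scatter), by contrast, stays within the scatter, so taking the carbonyl-bearing group off the ring nitrogen altogether made no clear difference.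

Compound 4 `O=C(Nc1nc(-c2ccccc2)nc2c1nnn2Cc1ccccc1)c1ccc(C(F)(F)F)cc1` has not yet been measured. It differs from compound 2 in one place: 4-(trifluoromethyl)phenyl in place of 2-(trifluoromethyl)phenyl on a carbonyl carbon. The same atoms are kept and only the spot where the trifluoromethyl group sits on its ring changes. Within the data shown here, no measured step tests such a move. The step from compound 1 to compound 2 exchanges one substituted ring for a differently substituted one, and the step from compound 1 to compound 3 removes the whole carbonyl-bearing group. Where compound 4 will land in this assay is therefore open, and the estimate below is wide. Compound 4 is expected to give about 1500 nM in this assay, somewhere between 400 nM and 6000 nM. In other words, the step of a 2.7-fold higher number from compound 2 to compound 4 (0.43 log units; beyond the scatter) is the expected outcome, with a real chance that it falls within the scatter.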

Compound 4, inhibition constant: 4210 nM
The estimate for compound 4 lay 2.8-fold (0.45 log units) below the measured number; the range from low to high includes it.
By their numbers in this assay, from the lowest: compound 2; then compounds 4, 3 and 1 (each within the scatter of the next).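

Moving the trifluoromethyl group on its ring, with the same atoms kept, matters in this assay: 4-(trifluoromethyl)phenyl in place of 2-(trifluoromethyl)phenyl on the carbonyl carbon gives a 7.5-fold higher number from compound 2 to compound 4 (0.88 log units; beyond the scatter) and so undoes the advantage of compound 2. This means that the lower number of compound 2 cannot be credited to the mere presence of a trifluoromethyl group on this ring, since the arrangement in which that group sits counts as well. The other new step, a 1.2-fold lower number from compound 1 to compound 4 (0.06 log units; within the scatter), shows no clear difference between the 4-(trifluoromethyl)phenyl and 3-nitrophenyl groups, which leaves compound 2 alone apart from compounds 1, 3 and 4, and nothing available explains why the spot on the ring has this effect.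

Still open, going by these compounds, is whether the lower number depends on the trifluoromethyl group itself, or whether a chlorine atom or a methoxy group at the same spot on the ring as in compound 2 would also give it. Also open, on these data alone, is where a plain phenyl ring with no substituent on the carbonyl carbon would fall, closer to compound 2 or to compound 4, which would show whether the 2-(trifluoromethyl)phenyl group truly helps.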